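The source may hold more compounds than are shown below. What is called first, only, known or untested is meant among the compounds shown, and "the series" means these compounds.

Compound 1 `O=C(N/N=C/c1cccc(Br)c1)Nc1ccc(Oc2ccnc3[nH]ccc23)c(F)c1` was tested in a functional assay on PC-3 cells (Homo sapiens) for antiproliferative activity, read by MTT assay, with a stated time of 72 h (on this read-out lower numbers stand for stronger inhibition and higher numbers for weaker inhibition), where compound 1 gives 4020 nM. Two close relatives differ from it only in the aromatic ring attached to the carbon with a double bond to nitrogen. Compound 2 `N#Cc1ccc(/C=N/NC(=O)Nc2ccc(Oc3ccnc4[nH]ccc34)c(F)c2)cc1` carries a 4-cyanophenyl there, and in this assay compound 2 gives 9030 nM. Compound 3 `COc1ccc(/C=N/NC(=O)Nc2ccc(Oc3ccnc4[nH]ccc34)c(F)c2)cc1` carries a 4-methoxyphenyl, and in this assay compound 3 gives 6730 nM. Among these three, compound 1 has the lowest number: the step of a 2.2-fold higher number from compound 1 to compound 2 (0.35 log units; beyond the scatter) lies beyond the scatter, whereas a 1.7-fold higher number from compound 1 to compound 3 (0.22 log units; within the scatter) and a 1.3-fold lower number from compound 2 to compound 3 (0.13 log units; within the scatter) do not.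

Compound 4 `O=C(N/N=C/c1ccc(O)c(Br)c1)Nc1ccc(Oc2ccnc3[nH]ccc23)c(F)c1` keeps the bromo group of compound 1 and adds one more group to that ring: hydroxy in place of hydrogen on an aromatic carbon. Among the measured compounds shown here, no measured pair shows exactly this change. For the measured compounds named here, the steps that bear on it are the swaps on the same ring, a 2.2-fold higher number from compound 1 to compound 2 (0.35 log units; beyond the scatter) and a 1.7-fold higher number from compound 1 to compound 3 (0.22 log units; within the scatter), both of which moved the number upward and only modestly. Hence the expected step of a 1.1-fold lower number from compound 1 to compound 4 (0.02 log units; within the scatter) in this assay is small, with no firm direction, and may well stay within the scatter. Compound 4 is therefore estimated at 3800 nM, with a likely range from 1600 nM to 9000 nM.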

Compound 4, half-maximal inhibitory concentration: 28600 nM
For compound 4 the middle estimate is 7.5-fold (0.88 log units) below the measured one; the whole stated range lies below it.
By their numbers in this assay, from the lowest: compounds 1, 3 and 2 (each within the scatter of the next, the first and the last beyond it); then compound 4.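

In this assay, this ring turns out to be less tolerant than the earlier swaps suggested. Adding a single hydroxy group to the 3-bromophenyl ring, ortho to the bromo group and para to a large group, gives a 7.1-fold higher number from compound 1 to compound 4 (0.85 log units; beyond the scatter), a larger step than any seen among compounds 1, 2 and 3. The 3-bromo-4-hydroxyphenyl ring also compares poorly with the two other rings, at a 4.2-fold higher number from compound 3 to compound 4 (0.63 log units; beyond the scatter) and a 3.2-fold higher number from compound 2 to compound 4 (0.50 log units; beyond the scatter), which makes compound 4 the weakest of the four, and no measurement offered here accounts for this loss of activity.

The compounds shown leave open whether the rise belongs to the hydroxy group alone or to its pairing with the bromo group, as every ring here that carries a hydroxy group also carries a bromo group. From the compounds shown here alone, it also remains open whether an amine or a carboxylic acid in the same place would raise the number as well, or whether a simple phenyl ring carrying only a hydroxy group would match compound 1 more closely.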